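Hydroxyethyl-to-isopropyl swap on two quinone-terpene cores

The compounds below may be only part of what the source reports. "The series", "measured", "known", "first", "only" and "open" are said of these compounds alone.

The series pairs an amino-acid-bearing quinone with two isomeric terpene cores. Compound 1 `C=C1[C@H](C)CCC[C@]1(C)CC/C(C)=C/CC1=C(O)C(=O)C=C(N[C@@H](C(=O)O)C(C)C)C1=O` and compound 2 `C=C1[C@H](C)CCC[C@]1(C)CC/C(C)=C/CC1=C(O)C(=O)C=C(N[C@@H](C(=O)O)[C@H](C)O)C1=O` share one core; compound 3 `CC1=CCC[C@](C)(CC/C(C)=C/CC2=C(O)C(=O)C=C(N[C@H](C(=O)O)[C@H](C)O)C2=O)[C@@H]1C` and the unmeasured compound 4 `CC1=CCC[C@](C)(CC/C(C)=C/CC2=C(O)C(=O)C=C(N[C@H](C(=O)O)C(C)C)C2=O)[C@@H]1C` share the other. The difference between the two cores is not broken down here.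

In an ADME assay on KB cells (Homo sapiens) for cytotoxicity, with a stated time of 48 h (on this read-out lower numbers stand for stronger inhibition and higher numbers for weaker inhibition), compound 1 gives 6.2 ug/mL. For compound 2 the read-out is only a limit of the assay, > 10 ug/mL. For compound 3 likewise only a limit is recorded, > 10 ug/mL. Two of the three values sit at the limit of > 10 ug/mL in this assay, at which 2 of the 3 values shown sit, so the measured step rests on one numbered value against a limit.

The change from compound 2 to compound 1 is isopropyl in place of 1-hydroxyethyl on a saturated chain carbon bound to an amine nitrogen and a carbonyl carbon, and it gives an at least 1.6-fold lower number from compound 2 to compound 1 (0.20 log units; that floor lies within the scatter). The same change, at the same place, is made from compound 3 to compound 4: isopropyl in place of 1-hydroxyethyl on a saturated chain carbon bound to an amine nitrogen and a carbonyl carbon. Whether the core carrying the endocyclic double bond behaves as the other core does cannot be read from compound 3 and compound 2, both of which sit at the limit.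

Compound 4 is expected to move by an at least 1.5-fold lower number from compound 3 to compound 4 (0.18 log units; that floor lies within the scatter), resting on the step of the same change on the other core, an at least 1.6-fold lower number from compound 2 to compound 1 (0.20 log units; that floor lies within the scatter), whose floor lies within the scatter. Compound 4 is estimated at 6.5 ug/mL, with a range from 3 ug/mL to 12 ug/mL, and a real chance that the assay again reports only a limit.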

Compound 4, half-maximal inhibitory concentration: > 10 ug/mL
Compound 4 gave a limit, no number; the forecaster's own chance of this, stated with the estimate: 30%; middle value at least 1.5-fold (0.18 log units) away from the limit.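

In this assay compound 4 gives > 10 ug/mL, a limit of the assay and not a number. Compound 3 also carries only a limit, so no new step can be read between compound 3 and compound 4: the limit of > 10 ug/mL in this assay, at which 3 of the 4 values shown sit.

Still open, as far as these compounds go, is whether isopropyl in place of 1-hydroxyethyl shifts the read-out at all on the core of compound 3, and whether that core responds as the core of compound 1 does.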